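Swapping halogen positions on the aniline of compound 3

The source may hold more compounds than are shown below. What is called first, only, known or untested is meant among the compounds shown, and "the series" means these compounds.

The series shares one core, a trimethoxy-substituted bicyclic scaffold bearing an aniline. Compound 1 `COc1cc2c(Nc3ccc(F)c(Cl)c3F)ncnc2c(OC)c1OC` sits at the assay limit in a functional assay on SGC-7901 cells (Homo sapiens) for antiproliferative activity, read by MTT assay, with a stated time of 72 h (on this read-out lower numbers stand for stronger inhibition and higher numbers for weaker inhibition), giving > 30000 nM. Compound 2 `COc1cc2c(Nc3cccc(F)c3F)ncnc2c(OC)c1OC` likewise gives only a limit in this assay, > 30000 nM. Among the compounds with values here, compound 3 `COc1cc2c(Nc3ccc(F)c(Cl)c3)ncnc2c(OC)c1OC` is the sole member with a number: in this assay compound 3 gives 5420 nM, so it stands as the only quantified point. The values of compounds 1 and 2 are limits (the limit of > 30000 nM in this assay, at which 2 of the 3 values shown sit).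

The unmeasured compound 4 `COc1cc2c(Nc3ccc(Cl)cc3F)ncnc2c(OC)c1OC` rearranges the same atoms: 4-chloro-2-fluorophenyl in place of 3-chloro-4-fluorophenyl on a nitrogen on an aromatic ring. Within the data shown here, two measured steps bear on this change. an at least 5.5-fold lower number from compound 1 to compound 3 (0.74 log units; beyond the scatter), and an at least 5.5-fold lower number from compound 2 to compound 3 (0.74 log units; beyond the scatter); both show that moving from the halogen patterns of compounds 1 and 2 to the 3-chloro-4-fluorophenyl of compound 3 gave an at least modest gain. Compound 4 departs from that 3-chloro-4-fluorophenyl in favour of a 4-chloro-2-fluorophenyl, so the gain is not expected to carry over, and a step back toward the region where compounds 1 and 2 lie, beyond the scatter, is the expectation.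

The estimated step is a 3.7-fold higher number from compound 3 to compound 4 (0.57 log units; beyond the scatter). Compound 4 is therefore expected to give about 20000 nM in this assay, within a range from 6000 nM to 60000 nM, with a real chance of only a limit.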

Compound 4, half-maximal inhibitory concentration: > 30000 nM
Compound 4 gave a limit, no number; the forecaster's own chance of this, stated with the estimate: 45%; at least 1.5-fold (0.17 log units) between middle value and limit.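

With the atoms unchanged and only their arrangement different, the move from 3-chloro-4-fluorophenyl to 4-chloro-2-fluorophenyl on the nitrogen gave an at least 5.5-fold higher number from compound 3 to compound 4 (0.74 log units; beyond the scatter) in this assay. The earlier steps shown here compared compound 3 with anilines that differed in the number or kind of their halogens, so they could not separate the choice of halogens from their placement; this pair holds the halogens constant and shows that placement alone can decide whether a number is obtained. Within the data shown here, compound 4 gives only a limit, so the step from compound 2 to compound 4 cannot be read, and compound 3 remains the only compound with a number: the limit of > 30000 nM in this assay, at which 3 of the 4 values shown sit.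

From the compounds shown here alone, how far past that limit compounds 1, 2 and 4 lie stays open, so their three halogen patterns cannot be ranked against one another. Also open, going by these compounds, is whether a different group on this nitrogen, such as a 3-ethynylphenyl or a 3-methoxyphenyl, or a morpholine-bearing chain in place of one methoxy group on the shared core, would give a lower number than compound 3.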